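Benzyl for 3-aminophenyl on the aromatic nitrogen of compound 1

A few compounds are considered here, and "the series" means these few. Any claim that something is new, unique, unknown or untested is made for them only; others in the source may bear on it.

Measured compounds:
compound 1, `Nc1cccc(Nc2c(C(=O)NCc3ccc(F)cc3)nc(Br)c3cccnc23)c1`, in a functional assay on HCT-116 cells (Homo sapiens) for cytotoxicity, read by MTT assay, with a stated time of 72 h (on this read-out lower numbers stand for stronger inhibition and higher numbers for weaker inhibition), compound 1 gives > 10000 nM
compound 2, `CN(C)c1ccc(CNC(=O)c2nc(Br)c3cccnc3c2N[C@H]2CC[C@H](N)CC2)cc1`, in this assay compound 2 gives "not determined" (no result reported)
compound 3, `N[C@H]1CC[C@H](Nc2c(C(=O)NCc3cccs3)nc(Br)c3cccnc23)CC1`, in this assay compound 3 gives "not determined" (no result reported)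

Compound 1 stands only at a limit of this assay, not at a number: the limit of > 10000 nM in this assay, at which 1 of the 3 values shown sits. Going by the values given here, compounds 2 and 3 carry no result, so no step between measured compounds can be drawn, and compound 1 is the only anchor for what follows.

Compound 4, `O=C(NCc1ccc(F)cc1)c1nc(Br)c2cccnc2c1NCc1ccccc1`, differs from compound 1 in one place: benzyl in place of 3-aminophenyl on a nitrogen on an aromatic ring. Since compound 1 offers only a limit, the size of the step from compound 1 to compound 4 cannot be read from the data; it is expected to be small, or none beyond the scatter, with no firm direction.

Compound 4 is therefore expected to give about 10000 nM, within 3000 nM to 30000 nM, meaning an expected step of a number no higher from compound 1 to compound 4 (the limit leaves the size open), with a fair chance that this assay again reports only a limit for compound 4.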

Compound 4, half-maximal inhibitory concentration: > 20000 nM
Compound 4: a limit, no number; the forecaster's own chance of this, stated with the estimate: 60%; middle value at least 2.0-fold (0.30 log units) away from the limit.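

In this assay, going by these compounds alone, compound 1 and compound 4 both stand only at limits, and no step between them can be read. The compounds shown leave open whether 3-aminophenyl and benzyl on that nitrogen differ at all in this assay.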